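From an amide to a sulfonamide on the shared core

A few compounds are considered here, and "the series" means these few. Any claim that something is new, unique, unknown or untested is made for them only; others in the source may bear on it.

Compound 2, with structure `O=C(Nc1cccc(/C=C/C(=O)c2nc3ccccc3[nH]2)c1)c1cc(Cl)cc(Cl)c1`, was tested in a functional assay on MCF7 cells (Homo sapiens) for antiproliferative activity, read by MTT assay, with a stated time of 48 h; a lower number here means a stronger inhibitor, a higher number a weaker inhibitor. For compound 2 the result is only a limit, > 100000 nM, not a number. Compound 1, with structure `Cc1cccc(C(=O)Nc2cccc(/C=C/C(=O)c3nc4ccccc4[nH]3)c2)c1`, gives 5590 nM in this assay. Among the compounds with values here, the one measured step, an at least 17-fold higher number from compound 1 to compound 2 (1.25 log units; beyond the scatter), is a large loss, and it rests on (the limit of > 100000 nM in this assay, at which 1 of the 2 values shown sits). Compound 3, with structure `O=C(/C=C/c1cccc(NS(=O)(=O)c2ccccc2Cl)c1)c1nc2ccccc2[nH]1`, is not yet measured. It differs from compound 2 in one place: (2-chlorophenyl)sulfonyl in place of (3,5-dichlorophenyl)carbonyl on a nitrogen on an aromatic ring. Within the data shown here, no measured step covers this kind of change, and since compound 2 sits at a limit, the true size of any step from it cannot be read off. The step from compound 2 to compound 3 is expected to be an at least 2.0-fold lower number from compound 2 to compound 3 (0.30 log units; that floor lies within the scatter), carrying wide uncertainty. Compound 3 is estimated to give 50000 nM in this assay, within a range from 5000 nM to 200000 nM.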

Compound 3, half-maximal inhibitory concentration: 4280 nM
For compound 3 the middle estimate is 12-fold (1.07 log units) above the measured one, outside the stated range (below it).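

The nitrogen on the aromatic ring can carry a sulfonyl group as well as a carbonyl group and still give a measurable effect in this assay: the swap on compound 2 gives an at least 23-fold lower number from compound 2 to compound 3 (1.36 log units; beyond the scatter). Measured against the (3-methylphenyl)carbonyl group, the change gives a 1.3-fold lower number from compound 1 to compound 3 (0.12 log units; within the scatter), and compound 1 and compound 3 cannot be told apart in this assay. The first step gives only a floor for the true size of the change, since compound 2 sits at a limit and not at a number: the limit of > 100000 nM in this assay, at which 1 of the 3 values shown sits.

Both steps change the link and the ring's substituents together, and the compounds shown do not separate the two; a (3,5-dichlorophenyl)sulfonyl group would help to do so. On these data alone, whether a phenyl ring carrying an amine or a carboxylic acid fits at this nitrogen also stays open.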